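Amide nitrogen substituent and cytotoxicity: returning from benzyl to aryl

The source may hold more compounds than are shown below. What is called first, only, known or untested is meant among the compounds shown, and "the series" means these compounds.

Measured in an ADME assay on HepG2 2.2.15 cells (Homo sapiens) for cytotoxicity, read by MTT assay, with stated times of 48 h and 9 days (on this read-out higher numbers stand for lower toxicity in this test and lower numbers for higher toxicity in this test), so far:
- compound 1 `COc1ccc2c(=O)c(/C=C/C(=O)Nc3ccccc3Cl)coc2c1`: 1010000 nM
- compound 2 `COc1ccc2c(=O)c(/C=C/C(=O)Nc3cc(C)ccc3C)coc2c1`: 1100000 nM
- compound 3 `COc1ccc2c(=O)c(/C=C/C(=O)NCc3ccccc3F)coc2c1`: 146000 nM

Compound 3 holds the lowest number of the measured set. The steps of a 6.9-fold lower number from compound 1 to compound 3 (0.84 log units; beyond the scatter) and a 7.5-fold lower number from compound 2 to compound 3 (0.88 log units; beyond the scatter) are both beyond the scatter, whereas a 1.1-fold higher number from compound 1 to compound 2 (0.04 log units; within the scatter) is within it, so the two aryl amides of compound 1 and compound 2 sit together and the benzyl amide of compound 3 sits apart.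

Compound 4 `COc1ccc2c(=O)c(/C=C/C(=O)Nc3ccc(Cl)cc3)coc2c1` differs from compound 3 by 4-chlorophenyl in place of 2-fluorobenzyl on an amide-type nitrogen. The bearing steps are the two already named: each exchanged an aryl group on the amide nitrogen for the 2-fluorobenzyl group and lowered the number by a modest amount. Compound 4 reverses that exchange, placing a chlorine-bearing phenyl group on the nitrogen, as compound 1 has. A rise of about the same size is therefore expected in this assay, a 6.8-fold higher number from compound 3 to compound 4 (0.84 log units; beyond the scatter), in the direction of compound 1 and compound 2. Compound 4 is estimated at 1000000 nM, with a range of 400000 nM to 2500000 nM.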

Compound 4, half-maximal cytotoxic concentration: 272000 nM
Compound 4: middle estimate off by 3.7-fold (0.57 log units), on the high side; the whole stated range lies above it.
By their numbers in this assay, from the lowest: compounds 3 and 4 (each within the scatter of the next); then compounds 1 and 2 (each within the scatter of the next).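

In this assay an aryl group on the amide-type nitrogen does not by itself set the number: a 1.9-fold higher number from compound 3 to compound 4 (0.27 log units; within the scatter) places the 4-chlorophenyl amide with the 2-fluorobenzyl amide, so the earlier split between aryl and benzyl amides does not hold for compound 4. The aryl amides no longer form one group, with a 3.7-fold lower number from compound 1 to compound 4 (0.57 log units; beyond the scatter) and a 4.0-fold lower number from compound 2 to compound 4 (0.61 log units; beyond the scatter) showing that the substitution on the phenyl group matters here, including between 2-chlorophenyl and 4-chlorophenyl. No accompanying measurement bears on why these numbers differ.

Still open, from the compounds shown here alone, is how a 4-chlorobenzyl group on the amide-type nitrogen would compare with compound 4, a single change that would test the benzyl link with the chlorine held in place. Also open, going by these compounds, is how a longer chain such as 2-phenylethyl, or a phenyl group carrying a carboxylic acid, would read in this assay on this nitrogen.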